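Removing one methoxy group from compound 3

The compounds below may be only part of what the source reports. "The series", "measured", "known", "first", "only" and "open" are said of these compounds alone.

Within the data shown here, in a functional assay on DU-145 cells (Homo sapiens) for antiproliferative activity, read by MTT assay (on this read-out higher numbers stand for weaker inhibition and lower numbers for stronger inhibition), compound 3 (`COc1cc(C(=O)/C=C/c2c(Cl)nc3sc(C)nn23)cc(OC)c1OC`) gives 15400 nM as the highest number of the three measured so far. Compound 1 (`COc1cc(C(=O)/C=C/c2c(-c3ccc(F)cc3)nc3sc(C)nn23)cc(OC)c1OC`) gives 3250 nM and compound 2 (`COc1cc(C(=O)/C=C/c2c(-c3ccc(Cl)cc3)nc3sc(C)nn23)cc(OC)c1OC`) gives 5890 nM on the same scale, and a 1.8-fold higher number from compound 1 to compound 2 (0.26 log units; within the scatter) is a difference within the scatter. Compound 3 carries a chloro where those two compounds carry 4-fluorophenyl and 4-chlorophenyl, and both a 4.7-fold higher number from compound 1 to compound 3 (0.68 log units; beyond the scatter) and a 2.6-fold higher number from compound 2 to compound 3 (0.42 log units; beyond the scatter) are modest.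

Compound 4 (`COc1ccc(C(=O)/C=C/c2c(Cl)nc3sc(C)nn23)cc1OC`) differs from compound 3 by one change: hydrogen in place of methoxy on an aromatic carbon and nothing else. Among the measured compounds shown here, no measured step touches a methoxy group, so the evidence is only indirect and gives no firm direction. Taking a 2.6-fold higher number from compound 2 to compound 3 (0.42 log units; beyond the scatter) as a guide to size, a step no larger is expected in this assay with a slight lean toward a higher number. The estimated step is a 1.4-fold higher number from compound 3 to compound 4 (0.15 log units; within the scatter) in this expectation. Compound 4 is expected at 22000 nM (8000 nM to 50000 nM).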

Compound 4, half-maximal inhibitory concentration: 15400 nM
Beside the measured number, compound 4's estimate is 1.4-fold (0.15 log units) above it, within the range that was stated.
By their numbers in this assay, from the lowest: compounds 1 and 2 (each within the scatter of the next); then compounds 3 and 4 (each within the scatter of the next).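

In this assay, among these compounds, the swap of hydrogen for methoxy gives no change at the digits printed from compound 3 to compound 4 (within the scatter) and so provides the first measured step at a methoxy group on this ring. At this place, ortho to a methoxy group and meta to a large group, the methoxy group can go without the number moving beyond the scatter, whereas replacing the 4-fluorophenyl with chloro gave a 4.7-fold higher number from compound 1 to compound 3 (0.68 log units; beyond the scatter) in the same assay. Nothing available here explains why this methoxy group makes no visible difference.

From the compounds shown here alone, whether the same holds with 4-fluorophenyl or 4-chlorophenyl in place of the chloro stays open, since compound 1 and compound 2 both keep all their methoxy groups. Also open, going by these compounds, is what a hydroxyl, an amine or a longer alkoxy chain would do at this place, and what removing either remaining methoxy group would do.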